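This account rests on a few compounds, and the source may have more. Where it says the series, first, only, none or still open, it means among the compounds named here.

In an ADME assay on L929 cells (Mus musculus) for cytotoxicity, read by resazurin assay, with a stated time of 48 h (a lower number here means that less compound is tolerated, a higher number that more compound is tolerated), compound 1 `C=CCn1c2ccc([N+](=O)[O-])cc2c(=O)n1Cc1ccccc1` gives 192000 nM. Compound 2 `N#CCn1c2ccc([N+](=O)[O-])cc2c(=O)n1Cc1ccccc1` reads > 256000 nM, which is a limit. Compound 3 `O=C(O)CCn1c2ccc([N+](=O)[O-])cc2c(=O)n1Cc1ccccc1` reads > 256000 nM, also only a limit. Compound 3 thus sits at the limit of > 256000 nM in this assay, at which 2 of the 3 values shown sit.

Compound 4 `NC(=O)CCCn1c2ccc([N+](=O)[O-])cc2c(=O)n1Cc1ccccc1` carries carbamoylmethyl in place of carboxy on a saturated chain carbon, two bonds along the chain from an aromatic nitrogen, that is, carbamoylmethyl in place of carboxy on a saturated chain carbon, two bonds along the chain from an aromatic nitrogen.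

The steps bearing on this change the same chain: an at least 1.3-fold higher number from compound 1 to compound 2 (0.12 log units; that floor lies within the scatter), an at least 1.3-fold higher number from compound 1 to compound 3 (0.12 log units; that floor lies within the scatter), and a step that the two limits leave unreadable from compound 2 to compound 3. None shows a change beyond the scatter in this assay, so no real shift is expected, and another limit reading is likely.

The expected step is a number no higher from compound 3 to compound 4 (the limit leaves the size open). For compound 4 the estimate is 256000 nM, with an expected range of 130000 nM to 500000 nM.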

Compound 4, concentration lethal to 50% of the cells: > 256000 nM
Compound 4 ended at the assay's limit; the forecaster's own chance of this, stated with the estimate: 65%; the middle value lies on the limit itself.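

In this assay, a third chain end, 2-carbamoylethyl, also stays at a limit, alongside the cyano and carboxy compounds: the limit of > 256000 nM in this assay, at which 3 of the 4 values shown sit. Against the vinyl end, the change gives an at least 1.3-fold higher number from compound 1 to compound 4 (0.12 log units; that floor lies within the scatter), so no separation from compound 1 beyond the scatter is shown. The steps from compound 2 and from compound 3 to compound 4 cannot be read, as both ends of each are limits.

Still open, going by these compounds, is whether a terminal amine or a longer chain at this place would give a number inside the range of this assay. On these data alone, how far compound 2, compound 3 and compound 4 lie from one another also stays unknown.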